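This account rests on a few compounds, and the source may have more. Where it says the series, first, only, none or still open, it means among the compounds named here.

In a functional assay on ECa-109 cells (Homo sapiens) for cytotoxicity, read by MTT assay, with a stated time of 72 h (a higher number here means a weaker inhibitor, a lower number a stronger inhibitor), three compounds sharing one core have been measured. For compound 1 (`CN(C)c1ccc(C=C2C(=O)N(c3ccc(Cl)cc3)N(c3ccc(Cl)cc3)C2=O)cc1`) the result is a limit of the assay, not a number: > 128000 nM. Compound 2 (`O=C1C(=Cc2ccc(F)cc2)C(=O)N(c2ccc(Cl)cc2)N1c1ccc(Cl)cc1`) gives 35600 nM, and compound 3 (`COc1cccc(C=C2C(=O)N(c3ccc(Cl)cc3)N(c3ccc(Cl)cc3)C2=O)c1`) gives 29000 nM. Compound 3 therefore stands level with compound 2, since a 1.2-fold lower number from compound 2 to compound 3 (0.09 log units; within the scatter) lies within the scatter.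

Compound 4 (`COc1ccc(C=C2C(=O)N(c3ccc(Cl)cc3)N(c3ccc(Cl)cc3)C2=O)cc1OC`) has not yet been measured. It differs from compound 3 by methoxy in place of hydrogen on an aromatic carbon, ortho to a methoxy group and para to a large group, which turns 3-methoxyphenyl into 3,4-dimethoxyphenyl.

Among the measured compounds shown here, no measured step makes this exact change, so the evidence is indirect. The closest guide is a 1.2-fold lower number from compound 2 to compound 3 (0.09 log units; within the scatter), a swap of aryl groups that moved the number by no more than the scatter. The steps of an at least 3.5-fold lower number from compound 1 to compound 2 (0.55 log units; beyond the scatter) and an at least 4.4-fold lower number from compound 1 to compound 3 (0.64 log units; beyond the scatter) are larger, but both start from a limit and give only bounds. On this basis, no change beyond the scatter is expected in this assay, with a slight lean towards a higher number. The expected step is a 1.4-fold higher number from compound 3 to compound 4 (0.14 log units; within the scatter). For compound 4 the estimated value is 40000 nM, with an expected range from 18000 nM to 100000 nM.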

Compound 4, half-maximal inhibitory concentration: > 128000 nM
Compound 4 was reported as a limit; the forecaster's own chance of this, stated with the estimate: 15%; middle value at least 3.2-fold (0.50 log units) away from the limit.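

In this assay, methoxy in place of hydrogen on an aromatic carbon, ortho to a methoxy group and para to a large group, gives an at least 4.4-fold higher number from compound 3 to compound 4 (0.64 log units; beyond the scatter), the first change shown on this carbon that starts from a measured number and moves it beyond the scatter. The aryl group therefore matters more than the earlier swap suggested: that swap gave a 1.2-fold lower number from compound 2 to compound 3 (0.09 log units; within the scatter), whereas 3,4-dimethoxyphenyl in place of 4-fluorophenyl gives an at least 3.5-fold higher number from compound 2 to compound 4 (0.55 log units; beyond the scatter). Compound 1 and compound 4 both stand at a limit of the assay, so the step between them cannot be read: the limit of > 128000 nM in this assay, at which 2 of the 4 values shown sit.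

The compounds shown leave open whether the loss needs both methoxy groups, since a 4-methoxyphenyl group would separate the effect of the group on this carbon from that of the methoxy group already on the ring, and whether a hydroxy group or a carboxylic acid on the same carbon would also reach the limit. Going by these compounds, how far compound 4 lies past its limit also remains unknown, so the full size of the step cannot be told.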